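The source may report more compounds than this note shows. Statements on the series, on what has been measured and on what is new or still open speak of the compounds shown alone.

Working notes on the series, values in an ADME assay on MRC5 cells (Homo sapiens), read by MTT assay, with a stated time of 72 h; on this read-out lower numbers stand for stronger inhibition and higher numbers for weaker inhibition:

- Compound 1 `CSc1ncnc2c1c(-c1ccoc1)cn2[C@@H]1O[C@H](CO)[C@@H](O)[C@H]1O`: > 100000 nM (a limit)
- Compound 2 `CSc1ncnc2c1c(-c1cccs1)cn2[C@@H]1O[C@H](CO)[C@@H](O)[C@H]1O`: > 100000 nM (a limit)
- Compound 3 `CNc1ncnc2c1c(-c1ccco1)cn2[C@@H]1O[C@H](CO)[C@@H](O)[C@H]1O`: 90800 nM

Going by the values given here, compound 3 gives the only actual number in this assay, at 90800 nM. The other two entries are not numbers: the limit of > 100000 nM in this assay, at which 2 of the 3 values shown sit.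

The next compound is compound 4 `CNc1ncnc2c1c(-c1ccoc1)cn2[C@@H]1O[C@H](CO)[C@@H](O)[C@H]1O`. The change is furan-3-yl in place of furan-2-yl on an aromatic carbon, with furan-3-yl in place of furan-2-yl on an aromatic carbon and the same atoms joined differently.

Among the compounds with values here, the one measured step that swaps the group at this place is a step that the two limits leave unreadable from compound 1 to compound 2, so it offers no size to carry over. Compound 1 also carries furan-3-yl, and it reports only a limit, > 100000 nM. Within the data shown here, no measured step therefore argues for a shift in either direction in this assay, and none beyond the usual scatter is expected. The expectation rests on compound 3 at 90800 nM as the anchor. A reading of compound 4 as a bare limit is about as plausible as a number.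

The expected change is a 1.0-fold lower number from compound 3 to compound 4 (0.00 log units; within the scatter), which is an estimate only. For compound 4 the estimated value is 90000 nM, with an expected range from 45000 nM to 160000 nM.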

Compound 4, half-maximal inhibitory concentration: > 100000 nM
Compound 4 ended at the assay's limit (the forecaster's own chance of this, stated with the estimate: 45%); middle value at least 1.1-fold (0.04 log units) from the limit.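

In this assay, furan-3-yl in place of furan-2-yl on an aromatic carbon, with the same atoms joined differently, gives an at least 1.1-fold higher number from compound 3 to compound 4 (0.04 log units; that floor lies within the scatter). Going by these compounds alone, this is the first readable step at this place, but it is only a floor that lies within the scatter, so it fixes a direction at most weakly and gives no true size; the furan-3-yl compound with methylamino does not yield a number any more than compound 1 does, and the steps between two limits, including the change from methylsulfanyl to methylamino, cannot be read. The series now sits mostly at the top of the measurable range, and the only number rests on the single furan-2-yl compound: the limit of > 100000 nM in this assay, at which 3 of the 4 values shown sit.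

What the compounds shown leave open is whether any group on this aromatic carbon can bring a clear number into this assay, for instance a phenyl ring, a carboxylic acid or an aminomethyl chain. Also open, going by these compounds, is whether a larger amine such as dimethylamino in place of methylamino would separate furan-2-yl from furan-3-yl by more than the scatter.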